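This account rests on a few compounds, and the source may have more. Where it says the series, first, only, none or still open, it means among the compounds named here.

Of the compounds shown here, three have been measured so far in an ADME assay on HepG2 cells (Homo sapiens), read by MTT assay, with a stated time of 72 h, in the presence of a further agent that is not named here; on this read-out higher numbers stand for weaker inhibition and lower numbers for stronger inhibition. Compound 3 `O=C(NC1CCCCC1)Oc1ccc(Cl)cc1C(=O)Nc1ccc(F)cc1` gives 8600 nM. Compound 1 `O=C(Nc1ccccc1)Oc1ccc(Cl)cc1C(=O)Nc1ccc(F)cc1` differs from it only by phenyl in place of cyclohexyl on an amide-type nitrogen, and in this assay compound 1 gives 3250 nM. That single change produced a step of a 2.6-fold lower number from compound 3 to compound 1 (0.42 log units; beyond the scatter). Compound 2 `O=C(NC1CCCCC1)Oc1ccccc1C(=O)Nc1ccccc1` stands apart: in this assay compound 2 gives 51500 nM, the highest of the three numbers, and the difference between its core and the core of compound 3 is not broken down here. Compound 4 `O=C(Nc1ccccc1)Oc1ccccc1C(=O)Nc1ccccc1` has not yet been measured; it differs from compound 2 by phenyl in place of cyclohexyl on an amide-type nitrogen, the same change at the same kind of place as before. Because that earlier change gave a 2.6-fold lower number from compound 3 to compound 1 (0.42 log units; beyond the scatter), a step of similar size is expected here, namely a 2.6-fold lower number from compound 2 to compound 4 (0.41 log units; beyond the scatter). Compound 4 is therefore estimated at 20000 nM, most likely between 8000 nM and 50000 nM.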

Compound 4, half-maximal inhibitory concentration: 26800 nM
Compound 4: middle estimate off by 1.3-fold (0.13 log units), on the low side, and the stated range covers the measured number.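

Replacing cyclohexyl with phenyl on the amide-type nitrogen gives a 1.9-fold lower number from compound 2 to compound 4 (0.28 log units; within the scatter) in this assay, so this step alone cannot be told apart from the usual variation between repeat measurements. Set beside the earlier step, the change behaves alike on the two cores as far as these numbers can tell: the same change on two cores in this assay, a 2.6-fold lower number (0.42 log units; beyond the scatter) from compound 3 to compound 1 and a 1.9-fold lower number (0.28 log units; within the scatter) from compound 2 to compound 4, 1.4-fold (0.14 log units) apart, within the scatter of two such steps

Within the data shown here, this agreement rests on only two cores, so it does not show that the change would carry over to any other core, and it does not explain why the numbers move.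

Still open, as far as these compounds go, is what other groups on that nitrogen would do, such as a longer carbon chain or one bearing an amine. From the compounds shown here alone, a carboxylic acid there is equally open.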